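Removing a Methoxybenzyl Group on a Fused Pyrazole Core

The source may hold more compounds than are shown below. What is called first, only, known or untested is meant among the compounds shown, and "the series" means these compounds.

Compound 1 `N=C(Nc1ccccc1)c1cc2c(-c3ccccc3)n[nH]c2c(NC2CCCCC2)n1`: 850 nM
Compound 3 `COc1ccc(Cn2nc(-c3ccccc3)c3cc(C(=N)Nc4ccccc4)nc(NC4CCCCC4)c32)cc1`: 3400 nM
Compound 2 `COc1ccc(Cn2nc(-c3ccccc3)c3cc(C(=N)Nc4cccc(C(F)(F)F)c4)nc(Nc4cc(OC)c(OC)c(OC)c4)c32)cc1`: "not determined" (no result reported)

In a functional assay on HT-1080 cells (Homo sapiens) for cytotoxicity, read by MTT assay, with a stated time of 72 h (a lower number here means a stronger inhibitor, a higher number a weaker inhibitor), compound 3 gives 3400 nM, while compound 1 gives 850 nM. The step between them, a 4.0-fold lower number from compound 3 to compound 1 (0.60 log units; beyond the scatter), is hydrogen in place of 4-methoxybenzyl on an aromatic nitrogen. Compound 2 has no single number in this assay. How the cores of compound 2 and compound 3 differ is not broken down here. Compound 4 `COc1cc(Nc2nc(C(=N)Nc3cccc(C(F)(F)F)c3)cc3c(-c4ccccc4)n[nH]c23)cc(OC)c1OC` is to be measured in this assay; it arises from compound 2 by the same change, (hydrogen in place of 4-methoxybenzyl on an aromatic nitrogen), at the same place. Within the data shown here, the direction of the step in the first pair supports an expectation that compound 4 lands in the same region as compound 1, though no measured pair anchors it. Because compound 1 gives 850 nM after this change, compound 4 is expected to give about 1000 nM in this assay. For compound 4 the expected range is estimated as 200 nM to 5000 nM, and it is wide.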

Compound 4, half-maximal inhibitory concentration: 6700 nM
Estimate against measurement, compound 4: 6.7-fold (0.83 log units) below; the whole stated range lies below it.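

Compound 2 has no number in this assay to set against compound 4, so no step can be read between them. From the compounds shown here alone, whether removing 4-methoxybenzyl acts alike on both cores stays open, and no supporting data bear on this result.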